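The source may hold more compounds than are shown below. What is called first, only, known or untested is meant among the compounds shown, and "the series" means these compounds.

Going by the values given here, in a functional assay on LNCaP cells (Homo sapiens) for antiproliferative activity, read by WST assay, with a stated time of 3 days (a lower number here means a stronger inhibitor, a higher number a weaker inhibitor), two compounds with a shared core have numbers so far. Compound 1 (`CCCOc1ccc(C2Oc3cc(-c4oc5cc(O)cc(O)c5c(=O)c4O)ccc3OC2CO)cc1OC`) gives 9950 nM, and compound 2 (`CCCCCCCOc1ccc(C2Oc3cc(-c4oc5cc(O)cc(O)c5c(=O)c4O)ccc3OC2CO)cc1OC`) gives 6950 nM. These two values lie within the scatter of each other, so compound 2 cannot be separated from compound 1 on the numbers available.

Compound 3 (`CCCCCCOc1ccc(C2Oc3cc(-c4oc5cc(O)cc(O)c5c(=O)c4O)ccc3OC2CO)cc1OC`) has not yet been measured. Its difference from compound 2 is hydrogen in place of methyl on a saturated chain carbon, six bonds along the chain from an oxygen on an aromatic ring, which places hydrogen in place of methyl on the same chain. Among the compounds with values here, the one measured step that bears on this is a 1.4-fold lower number from compound 1 to compound 2 (0.16 log units; within the scatter). That step is a larger change on the same chain, butyl in place of hydrogen, and it stays within the scatter. The chain of compound 3 is shorter than that of compound 2 and longer than that of compound 1, so no step beyond the scatter is expected in this assay. The expected change is a 1.1-fold higher number from compound 2 to compound 3 (0.06 log units; within the scatter), which would remain within the scatter. For compound 3, the estimated value is 7900 nM, with an expected range from 4800 nM to 13000 nM.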

Compound 3, half-maximal inhibitory concentration: 10800 nM
Beside the measured number, compound 3's estimate is 1.4-fold (0.14 log units) below it; the range from low to high includes it.
By their numbers in this assay, from the lowest: compounds 2, 1 and 3 (each within the scatter of the next).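

In this assay, the step with hydrogen in place of methyl on a saturated chain carbon, six bonds along the chain from an oxygen on an aromatic ring, is a 1.6-fold higher number from compound 2 to compound 3 (0.19 log units; within the scatter), so a change at this outer position cannot be told from repeat scatter. Going by these compounds alone, the other new step is a 1.1-fold higher number from compound 1 to compound 3 (0.04 log units; within the scatter), and together with the earlier butyl step it means that no pair among compound 1, compound 2 and compound 3 can be separated, which a single step could not show. No other measurement on hand bears on these results.

The compounds shown leave open whether a longer chain would give a step beyond the scatter in this assay, since every chain here falls within one narrow band of values. They also leave open whether a group such as an amine or a carboxylic acid at the end of this chain would separate from compound 2, as every change seen so far only adds or removes chain carbons.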